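Oxazolidinone series: methoxy to triazolyl, cytotoxicity outlook

The source may hold more compounds than are shown below. What is called first, only, known or untested is meant among the compounds shown, and "the series" means these compounds.

In an ADME assay on HEK293-A cells (Homo sapiens) for cytotoxicity, read by MTT assay, with a stated time of 48 h (on this read-out higher numbers stand for weaker inhibition and lower numbers for stronger inhibition), compound 1 `CCN1CCN(C[C@H]2CN(c3ccc(-n4cc(-c5ccccn5)cn4)c(F)c3)C(=O)O2)CC1` gives 99 ug/mL. Compound 2 `COC[C@H]1CN(c2ccc(-n3cc(-c4ccccn4)cn3)c(F)c2)C(=O)O1` gives > 400 ug/mL, which is a limit of the assay and not a number. Among the compounds with values here, the only measured step, an at least 4.0-fold higher number from compound 1 to compound 2 (0.60 log units; beyond the scatter), ends at that limit (the limit of > 400 ug/mL in this assay, at which 1 of the 2 values shown sits). Compound 3 `O=C1O[C@@H](Cn2ccnn2)CN1c1ccc(-n2cc(-c3ccccn3)cn2)c(F)c1` carries 1H-1,2,3-triazol-1-yl in place of methoxy on a saturated chain carbon bound to a saturated ring carbon. Within the data shown here, no measured step covers this change, and the step from compound 1 to compound 2 shows only that compound 2 already sits at the limit. For compound 3 the expected step is a number no higher from compound 2 to compound 3 (the limit leaves the size open), none beyond the scatter. Compound 3 is therefore estimated at 400 ug/mL, with a range of 200 ug/mL to 800 ug/mL, and a limit value is expected to be the most likely report.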

Compound 3, half-maximal inhibitory concentration: 225 ug/mL
Compound 3: middle estimate off by 1.8-fold (0.25 log units), on the high side; low and high end bracket the measured number.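

In this assay compound 3 gives a number at this saturated chain carbon, whereas the methoxy compound 2 gives only a limit: the limit of > 400 ug/mL in this assay, at which 1 of the 3 values shown sits.

The change to 1H-1,2,3-triazol-1-yl reads as an at least 1.7-fold lower number from compound 2 to compound 3 (0.24 log units; that floor lies within the scatter), so no firm change from methoxy is shown. The replacement of 4-ethylpiperazin-1-yl reads as a 2.3-fold higher number from compound 1 to compound 3 (0.36 log units; beyond the scatter), so compound 1 keeps the lowest number of the three.

From the compounds shown here alone, the true distance between compound 2 and compound 3 stays open. So does the reading of a primary amine, a hydroxyl or a longer chain at this place.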